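Flipping the Linker and Trading Methoxy for Methyl

The source may report more compounds than this note shows. Statements on the series, on what has been measured and on what is new or still open speak of the compounds shown alone.

- compound 1 `COc1ccc(C(=O)/C=C/c2cc(-c3ccc(OC)c(OC)c3)n3nc(-c4ccccc4)cc3n2)cc1OC` gives 32500 nM in an ADME assay on HEK293 cells (Homo sapiens) for antiproliferative activity, read by MTT assay, with a stated time of 24 h; on this read-out lower numbers stand for stronger inhibition and higher numbers for weaker inhibition
- compound 2 `COc1ccc(C(=O)/C=C/c2cc(-c3ccc(OC)c(OC)c3)n3nc(-c4ccccc4)cc3n2)cc1` gives 40000 nM in this assay
- compound 3 `COc1ccc(/C=C/C(=O)c2cc(-c3ccc(OC)c(OC)c3)n3nc(-c4ccccc4)cc3n2)cc1` gives 50700 nM in this assay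

Compound 3 has the highest of the three numbers, but its gaps to compound 2 and to compound 1 both lie within the usual scatter, so none of the three can be told apart on this read-out. Compound 4 `COc1ccc(-c2cc(/C=C/C(=O)c3ccc(C)c(C)c3)nc3cc(-c4ccccc4)nn23)cc1OC` has not yet been measured. It differs from compound 3 in one place: 2-((3,4-dimethylphenyl)carbonyl)ethenyl in place of (2-(4-methoxyphenyl)ethenyl)carbonyl on an aromatic carbon. Among the measured compounds shown here, two measured steps bear on this. Exchanging the two ends of the linker gave a 1.3-fold higher number from compound 2 to compound 3 (0.10 log units; within the scatter), and removing a methoxy from an aryl ring gave a 1.2-fold higher number from compound 1 to compound 2 (0.09 log units; within the scatter); neither moved the number beyond the scatter. For the measured compounds named here, with no precedent for a shift beyond the scatter, compound 4 is expected to show a 1.1-fold lower number from compound 3 to compound 4 (0.05 log units; within the scatter). The estimate for compound 4 is therefore 45000 nM, with a likely range from 20000 nM to 100000 nM.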

Compound 4, half-maximal inhibitory concentration: 46200 nM
The estimate for compound 4 lay 1.0-fold (0.01 log units) below the measured number, and the stated range covers the measured number.
By their numbers in this assay, from the lowest: compounds 1, 2, 4 and 3 (each within the scatter of the next).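

The aryl ring at the far end of the linker can change along with the linker direction: 2-((3,4-dimethylphenyl)carbonyl)ethenyl in place of (2-(4-methoxyphenyl)ethenyl)carbonyl gives only a small shift (a 1.1-fold lower number from compound 3 to compound 4 (0.04 log units; within the scatter)) on the read-out of the assay (this assay). With the linker direction kept, methyl groups can also replace methoxy groups on that ring, as 3,4-dimethylphenyl in place of 4-methoxyphenyl (a 1.2-fold higher number from compound 2 to compound 4 (0.06 log units; within the scatter)) and in place of 3,4-dimethoxyphenyl (a 1.4-fold higher number from compound 1 to compound 4 (0.15 log units; within the scatter)) both stay within the scatter. No supporting measurement is available to explain these results.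

From the compounds shown here alone, whether a different kind of group on this ring, such as an amine or a carboxylic acid, would move the number beyond the scatter remains open. So does the question of which parts of these structures this read-out responds to at all.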